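The source may report more compounds than this note shows. Statements on the series, on what has been measured and on what is new or still open speak of the compounds shown alone.

In an ADME assay on microsomes from liver (Mus musculus) for metabolic stability, read by LC-MS, with a stated time of 10 min, tested at 0.5 uM (a higher number here means that more of the compound is left, a lower number that less of the compound is left), compound 1 (`c1ccc2c(c1)CN[C@H](CN(CCCN1CCNCC1)[C@H]1CCCc3cccnc31)C2`) gives 88% while compound 2 (`CC(C)N1CCN(CCCN(C[C@H]2Cc3ccccc3CN2)[C@H]2CCCc3cccnc32)CC1`) gives 58% and so holds the lower of the two numbers, with a gap beyond the usual scatter of repeated measurements. Compound 3 (`c1ccc2c(c1)CN[C@@H](CN(CCCCN1CCNCC1)[C@H]1CCCc3cccnc31)C2`) has not been measured yet. The structural change on going to it from compound 2 is (piperazin-1-yl)methyl in place of 4-isopropylpiperazin-1-yl on a saturated chain carbon, three bonds along the chain from an amine nitrogen on a saturated chain carbon, three bonds along the chain from an amine nitrogen. Cut one bond further out, the same change reads as 2-(4-isopropylpiperazin-1-yl)ethyl giving way to 3-(piperazin-1-yl)propyl. Among the measured compounds shown here, no two measured compounds differ in only one place, so no direct step can serve as a guide. For the measured compounds named here, the closest hint is compound 1, which also lacks the isopropyl group and gives 88% in this assay as its reading, but no measured compound carries the 3-(piperazin-1-yl)propyl group, so the expectation remains uncertain. An upward move beyond the scatter is expected, estimated as a number 20 percentage points higher from compound 2 to compound 3 (beyond the scatter) in this assay for this change. For compound 3 the estimated value is 78% (60% to 93%) as the likely range.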

Compound 3, percent of the compound remaining: 96%
Compound 3: middle estimate off by 18 percentage points, on the low side, outside the stated range (above it).
By their numbers in this assay, from the lowest: compound 2; then compounds 1 and 3 (each within the scatter of the next).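

In this assay, the change at this position, on a saturated chain carbon, three bonds along the chain from an amine nitrogen, gives the first directly readable step: a number 38 percentage points higher from compound 2 to compound 3 (beyond the scatter). This shows that more of the compound remains after the exchange of 2-(4-isopropylpiperazin-1-yl)ethyl for 3-(piperazin-1-yl)propyl, a large step for a change of only a few atoms. Nothing available explains why this number rises.

The step combines several differences at once: the isopropyl group is gone, the chain is longer, and the piperazine gains a hydrogen-bond donor, so these compounds cannot show how much each difference contributes. A compound with 3-(4-isopropylpiperazin-1-yl)propyl at this place would test the longer chain with the isopropyl group kept, while one with a smaller group such as 3-(4-methylpiperazin-1-yl)propyl would show whether any substituent on that piperazine nitrogen lowers the number, or only the isopropyl group.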